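Swapping the chlorobenzyl arm for cyclopropylmethyl

The source may hold more compounds than are shown below. What is called first, only, known or untested is meant among the compounds shown, and "the series" means these compounds.

Measured compounds:
compound 1 `Cc1cc(Nc2cc(-c3ccccc3)[nH]n2)n2nc(SCc3ccc(Cl)cc3)nc2n1` gives 8260 nM
compound 2 `CCCCCc1c(C)nc2nc(SCc3ccc(Cl)cc3)nn2c1Nc1cc(-c2ccccc2)[nH]n1` gives 6390 nM
compound 3 `Cc1nc2nc(SCc3ccc(Cl)cc3)nn2c(Nc2cc(-c3ccccc3)[nH]n2)c1C` gives 10600 nM

All three numbers come from a functional assay on MCF7 cells (Homo sapiens) for inhibition, read by MTT assay, with a stated time of 72 h; a lower number here means a stronger inhibitor, a higher number a weaker inhibitor. Compound 1 stands second highest of the three, and both neighbours lie within the usual scatter: the step of a 1.3-fold lower number from compound 1 to compound 2 (0.11 log units; within the scatter) and the step of a 1.3-fold higher number from compound 1 to compound 3 (0.11 log units; within the scatter) are each too small to call a real change. The step of a 1.7-fold higher number from compound 2 to compound 3 (0.22 log units; within the scatter) is likewise within the scatter. So across the measured set, adding pentyl or methyl on an aromatic carbon of the shared core left the result essentially unchanged.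

Compound 4 `Cc1cc(Nc2cc(-c3ccccc3)[nH]n2)n2nc(SCC3CC3)nc2n1` changes a different part of the molecule: cyclopropyl in place of 4-chlorophenyl on a saturated chain carbon bound to a sulfur. For the measured compounds named here, no measured step touches this position, so nothing here tells how the result responds to what sits beyond the sulfur. Going by the values given here, the only guide is that the series so far has been flat, with every step inside the scatter. The expectation for compound 4 is therefore a number close to that of compound 1, with a wide range to cover the lack of direct evidence; the expected step is a 1.2-fold higher number from compound 1 to compound 4 (0.08 log units; within the scatter). Compound 4 is estimated at 10000 nM, expected to fall between 3500 nM and 30000 nM.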

Compound 4, half-maximal inhibitory concentration: > 50000 nM
Compound 4: no number, only a limit; the forecaster's own chance of this, stated with the estimate: 15%; middle value at least 5.0-fold (0.69 log units) from the limit.
By their numbers in this assay, from the lowest: compounds 2, 1 and 3 (each within the scatter of the next). At a limit, above all of these: compound 4.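

Compounds 1, 2 and 3 differ only on an aromatic carbon of the shared core, and in this assay all their steps stay within the scatter, so they gave no reading of what lies beyond the sulfur. For compound 4 the result is a limit of the assay and not a number: the limit of > 50000 nM in this assay, at which 1 of the 4 values shown sits.

Even so, the step is clear, an at least 6.0-fold higher number from compound 1 to compound 4 (0.78 log units; beyond the scatter), which shows that this position responds where the earlier changes did not: with cyclopropyl in place of 4-chlorophenyl on the saturated chain carbon bound to the sulfur, inhibition of the cells falls off beyond the scatter.

This single swap changes the ring and removes the chlorine together, so the compounds shown cannot say which part of the change matters, or why inhibition is lost; a plain benzyl, a 4-fluorobenzyl or a longer chain such as hexyl on the sulfur would help to separate these. Going by these compounds, it also remains open whether cyclopropylmethyl would give the same loss on the cores of compound 2 and compound 3, which carry the pentyl and the extra methyl.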